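The compounds below may be only part of what the source reports. "The series", "measured", "known", "first", "only" and "open" are said of these compounds alone.

Measured in a functional assay on KB cells (Homo sapiens) for antiproliferative activity, read by MTT assay, with a stated time of 72 h; on this read-out higher numbers stand for weaker inhibition and lower numbers for stronger inhibition:
- compound 1 `CCOC(=O)c1cc(-c2cc(OC)c(OC)c(OC)c2)c(-c2ccc(OC)c([N+](=O)[O-])c2)s1`: 15800 nM
- compound 2 `COc1ccc(-c2sc(C(=O)O)cc2-c2cc(OC)c(OC)c(OC)c2)cc1`: 10400 nM
- compound 3 `COc1cc(-c2cc(C(=O)O)sc2-c2cccc(Br)c2)cc(OC)c1OC`: 32300 nM

All three values sit in a narrow band. In this assay, compound 2 at 10400 nM cannot be separated from compound 1 at 15800 nM, as the two lie within the usual scatter of each other. Compound 3 is set apart from it by a modest margin, a 3.1-fold higher number from compound 2 to compound 3 (0.49 log units; beyond the scatter).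

The next compound to be tested is compound 4 `COc1ccc(-c2sc(C(=O)O)cc2-c2cc(OC)c(OC)c(OC)c2)cc1[N+](=O)[O-]`. It differs from compound 2 in one place: nitro in place of hydrogen on an aromatic carbon. This is nitro in place of hydrogen on an aromatic carbon, ortho to a methoxy group and meta to a large group.

Within the data shown here, no measured step makes this exact change. Among the measured compounds shown here, the one step available, a 3.1-fold higher number from compound 2 to compound 3 (0.49 log units; beyond the scatter), alters the same ring in a different way, so it shows only that a modest shift is possible there. Compound 1 at 15800 nM does carry the nitro group, but as an ethyl ester rather than a carboxylic acid, and its value gives no sign of a large shift. Little movement is therefore expected in this assay, and no clear direction can be assigned. The expected change is a 1.2-fold higher number from compound 2 to compound 4 (0.06 log units; within the scatter), which would not stand out from the scatter. For compound 4 the estimated value is 12000 nM, with an expected range of 4000 nM to 35000 nM.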

Compound 4, half-maximal inhibitory concentration: 35900 nM
Beside the measured number, compound 4's estimate is 3.0-fold (0.48 log units) below it; the measured number lies above the stated range.
By their numbers in this assay, from the lowest: compounds 2 and 1 (each within the scatter of the next); then compounds 3 and 4 (each within the scatter of the next).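

In this assay, among these compounds, nitro in place of hydrogen, on an aromatic carbon ortho to a methoxy group and meta to a large group, gives a 3.5-fold higher number from compound 2 to compound 4 (0.54 log units; beyond the scatter) and so offers the first direct reading of this change, which moves toward weaker inhibition by a margin beyond the scatter. With the nitro group held in place, hydrogen in place of ethyl on an oxygen next to a carbonyl group gives a 2.3-fold higher number from compound 1 to compound 4 (0.36 log units; beyond the scatter) in the same direction, so the free carboxylic acid, read against the ethyl ester, also goes with weaker inhibition in this nitro-bearing pair. Nothing available explains either step.

As far as these compounds go, whether an amine, a fluorine or a second methoxy group at this same position would shift the number as nitro does remains open, so these two compounds cannot say whether the step belongs to nitro itself or to any substituent there. From the compounds shown here alone, it is also open whether the step from ethyl ester to carboxylic acid would keep its direction and size in the absence of the nitro group, or with a longer ester chain such as a butyl ester.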